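The source may hold more compounds than are shown below. What is called first, only, known or untested is meant among the compounds shown, and "the series" means these compounds.

Measured in an ADME assay on Caco-2 cells (Homo sapiens) for permeability, read by LC-MS, with a stated time of 2 h; a higher number here means that the compound crosses the layer faster, a lower number that the compound crosses the layer more slowly:
- compound 1 `COc1cc(CN(CC(C)C)C(CC(=O)O)c2ccc3c(c2)CCO3)ccc1OCCN1C(=O)CCC1=O`: 0.2 nm/s
- compound 2 `COc1cc(CN(CC(C)C)C(CC(=O)O)c2ccc(Cl)cc2)ccc1OCCN1C(=O)CCC1=O`: 3 nm/s

Of these two compounds, compound 2 stands higher, at 3 nm/s. Compound 3 `COc1cc(CN(CC(C)C)C(CC(=O)O)c2ccc(Cl)c(Cl)c2)ccc1OCCN1C(=O)CCC1=O` differs from it in one place: chloro in place of hydrogen on an aromatic carbon. In words, chloro replaces hydrogen on an aromatic carbon, turning 4-chlorophenyl into 3,4-dichlorophenyl.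

Among the measured compounds shown here, only one measured step bears on this change, and it does so loosely. That step, a 15-fold higher number from compound 1 to compound 2 (1.18 log units; beyond the scatter), is large, but it exchanged a whole group, while here a single atom is added to the 4-chlorophenyl group of compound 2. For the measured compounds named here, no measured step shows what a second chloro does, so a much smaller change is expected, with only a slight lean upward. The estimated step is a 1.3-fold higher number from compound 2 to compound 3 (0.12 log units; within the scatter). For compound 3 the expected value is 4 nm/s, with an estimated range from 1.5 nm/s to 11 nm/s.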

Compound 3, apparent permeability: 7 nm/s
Compound 3: middle estimate off by 1.8-fold (0.24 log units), on the low side, within the range that was stated.
By their numbers in this assay, from the lowest: compound 1; then compound 2; then compound 3.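

In this assay, one added chloro on the 4-chlorophenyl group gives a 2.3-fold higher number from compound 2 to compound 3 (0.37 log units; beyond the scatter), so this aromatic carbon responds to a change of a single heavy atom, and the step lies beyond the usual scatter of repeat measurements. The larger exchange of the whole group reads a 35-fold higher number from compound 1 to compound 3 (1.54 log units; beyond the scatter), which places the 3,4-dichlorophenyl group further from the group carried by compound 1 than the 4-chlorophenyl group stands, though that step alters many atoms at once. Nothing measured here explains why the number rises.

Going by these compounds, it remains open whether the rise belongs to chloro in particular or would also follow another group on the same aromatic carbon, such as fluoro, methyl or methoxy. On these data alone, it is equally open whether a second chloro elsewhere on the ring would give a similar step.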